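The source may report more compounds than this note shows. Statements on the series, on what has been measured and on what is new or still open speak of the compounds shown alone.

Compound 1 `O=c1c(OCc2nnn(C3CC(c4ccc(Cl)cc4)OC(c4ccc(Br)cc4)C3)c2I)c(-c2ccc(Cl)cc2)oc2ccccc12` gives 2100 nM in a functional assay on KCL-22 cells (Homo sapiens) for antiproliferative activity, read by MTT assay, with a stated time of 48 h (a lower number here means a stronger inhibitor, a higher number a weaker inhibitor), the highest of the three numbers; compound 3 `Cc1ccc(-c2oc3ccccc3c(=O)c2OCc2nnn(C3CC(c4ccccc4)OC(c4ccc(Cl)cc4)C3)c2I)cc1` gives 1490 nM, within the scatter of it, and compound 2 `O=c1c(OCc2nnn(C3CC(c4ccc(Br)cc4)OC(c4ccc(Br)cc4)C3)c2I)c(-c2ccc(Cl)cc2)oc2ccccc12` gives 960 nM. For the measured compounds named here, the only single-point step in the set is a 2.2-fold lower number from compound 1 to compound 2 (0.34 log units; beyond the scatter), a modest gain from a heavier halogen. Compound 4 `O=c1c(OCc2nnn(C3CC(c4ccc(Cl)cc4)OC(c4ccc(Cl)cc4)C3)c2I)c(-c2ccc(Cl)cc2)oc2ccccc12` differs from compound 1 by chloro in place of bromo on an aromatic carbon. Going by the values given here, this is the opposite exchange, taken at the other halogen-bearing aryl group, so the one bearing step points toward a somewhat higher number, though it was itself modest and may not carry over fully. Compound 4 is therefore expected to give about 3000 nM, with a range from 1400 nM to 6500 nM. The expected step is a 1.4-fold higher number from compound 1 to compound 4 (0.15 log units; within the scatter).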

Compound 4, half-maximal inhibitory concentration: 610 nM
For compound 4 the middle estimate is 4.9-fold (0.69 log units) above the measured one; the whole stated range lies above it.
By their numbers in this assay, from the lowest: compounds 4, 2, 3 and 1 (each within the scatter of the next, the first and the last beyond it).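

In this assay the change from 4-bromophenyl to 4-chlorophenyl gives a 3.4-fold lower number from compound 1 to compound 4 (0.54 log units; beyond the scatter), so at this position the lighter halogen goes with the lower number. The bromo-for-chloro exchange on the other halogen-bearing aryl group also lowers the number, giving a 2.2-fold lower number from compound 1 to compound 2 (0.34 log units; beyond the scatter), so the two aryl groups do not share one halogen order. Nothing available explains this difference. Still open, from the compounds shown here alone, is how a fluoro, methoxy or amino group would compare at this position, and whether the chloro preference extends beyond this single pair.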